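Amide substituent change from compound 3 to compound 4

A few compounds are considered here, and "the series" means these few. Any claim that something is new, unique, unknown or untested is made for them only; others in the source may bear on it.

Compound 1 `CCCc1cc2cc(Cl)cc(Cn3nc(C(=O)O)cc3C)c2o1` gives 25.1 nM in an assay on CHO-K1 cells for displacement of a labelled ligand from prostaglandin E2 receptor EP1 subtype (Homo sapiens), read by scintillation counting, with a stated time of 45 min; on this read-out higher numbers stand for weaker inhibition and lower numbers for stronger inhibition. For the measured compounds named here, compound 2 `Cc1cc(C(=O)O)nn1Cc1cc(Cl)cc2cc(C3CCCCC3)oc12` gives 3.98 nM in this assay, and the only single-point step measured so far is a 6.3-fold lower number from compound 1 to compound 2 (0.80 log units; beyond the scatter). Compound 3 `Cc1cc(C(=O)NC(C)C)nn1Cc1cc(Cl)cc2cc(-c3ccccc3)oc12` gives 10 nM in this assay. It holds the second highest of the three numbers: compound 1 stands nearest, with a higher number, and compound 2 furthest, with a lower number, both gaps beyond the scatter.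

Compound 4 `Cc1cc(C(=O)NCC2CCNCC2)nn1Cc1cc(Cl)cc2cc(-c3ccccc3)oc12` differs from compound 3 in one place: (piperidin-4-yl)methyl in place of isopropyl on an amide-type nitrogen. Going by the values given here, no measured step touches the amide nitrogen; the single available step concerns a group on an aromatic carbon of the shared core and does not bear on the present change. Among the compounds with values here, with no precedent on the amide side, the default expectation in this assay is a small step in either direction, not clearly beyond the scatter, and the range is kept wide. Compound 4 is therefore expected to give 12 nM in this assay, with a range from 3 nM to 50 nM. This corresponds to an estimated step of a 1.2-fold higher number from compound 3 to compound 4 (0.08 log units; within the scatter).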

Compound 4, half-maximal inhibitory concentration: 20 nM
Beside the measured number, compound 4's estimate is 1.7-fold (0.22 log units) below it, within the range that was stated.
By their numbers in this assay, from the lowest: compound 2; then compounds 3, 4 and 1 (each within the scatter of the next, the first and the last beyond it).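

On the amide-type nitrogen, (piperidin-4-yl)methyl in place of isopropyl gives a 2.0-fold higher number from compound 3 to compound 4 (0.30 log units; within the scatter) in this assay, the only step at this position among the compounds shown. The exchange adds a six-membered non-aromatic ring with 1 hetero atom, 1 hydrogen-bond donor and 1 hydrogen-bond acceptor, and the group grows from 3 to 7 heavy atoms, yet the step stays within the scatter, so this one pair shows that the amide nitrogen can carry the larger group. Nothing available bears on why the number stays within the scatter after this exchange.

On these data alone, whether the ring or its nitrogen counts for more stays open: cyclohexylmethyl on the same amide nitrogen would separate the two, as would open-chain aminoethyl. As far as these compounds go, whether the step holds with propyl or cyclohexyl in place of the phenyl group on the core also stays open.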